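Series notes: piperidin-1-yl variant of compound 3

The source may hold more compounds than are shown below. What is called first, only, known or untested is meant among the compounds shown, and "the series" means these compounds.

Of the compounds shown here, three sharing one core have been measured in an assay on liver for inhibition of sterol O-acyltransferase 1 (Rattus norvegicus), using microsomes; on this read-out lower numbers stand for stronger inhibition and higher numbers for weaker inhibition. Compound 1 `CC(C)c1cccc(C(C)C)c1NC(=O)NS(=O)(=O)N(C)C` gives 3900 nM. Compound 2 `CCCN(CCC)S(=O)(=O)NC(=O)Nc1c(C(C)C)cccc1C(C)C` gives 1100 nM, and compound 3 `CCCCN(CC)S(=O)(=O)NC(=O)Nc1c(C(C)C)cccc1C(C)C` gives 1200 nM. Among these three numbers compound 3 stands second highest; compound 2 lies nearest to it, within the scatter, and compound 1 furthest, beyond the scatter.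

Compound 4 `CC(C)c1cccc(C(C)C)c1NC(=O)NS(=O)(=O)N1CCCCC1` is not yet measured. Its change from compound 3 is piperidin-1-yl in place of butyl(ethyl)amino on a sulfonyl sulfur. The measured steps that bear on this all concern the amino group on the same sulfonyl sulfur: replacing dimethylamino by a larger group gave a 3.5-fold lower number from compound 1 to compound 2 (0.55 log units; beyond the scatter) and a 3.3-fold lower number from compound 1 to compound 3 (0.51 log units; beyond the scatter), whereas exchanging one larger amino group for another gave a 1.1-fold higher number from compound 2 to compound 3 (0.04 log units; within the scatter). Compound 4 keeps a larger amino group rather than returning to dimethylamino, so the expectation in this assay is a step of the second kind: none beyond the scatter, with no clear direction. The estimate for compound 4 is therefore 1500 nM, expected to lie between 600 nM and 4000 nM. This estimate means an expected step of a 1.3-fold higher number from compound 3 to compound 4 (0.10 log units; within the scatter) in this assay, within the scatter.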

Compound 4, half-maximal inhibitory concentration: 17000 nM
Beside the measured number, compound 4's estimate is 11-fold (1.05 log units) below it; measured number above the stated range.
By their numbers in this assay, from the lowest: compounds 2 and 3 (each within the scatter of the next); then compound 1; then compound 4.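

In this assay, tying the amino group on the sulfonyl sulfur into a piperidin-1-yl ring gives a 14-fold higher number from compound 3 to compound 4 (1.15 log units; beyond the scatter) and a 15-fold higher number from compound 2 to compound 4 (1.19 log units; beyond the scatter) so this position is far less tolerant than the two open-chain groups suggested. The number also rises past that of the dimethylamino group, with a 4.4-fold higher number from compound 1 to compound 4 (0.64 log units; beyond the scatter) and a larger amino group therefore does not by itself lower the number: the dipropylamino and butyl(ethyl)amino groups follow that pattern, while the piperidin-1-yl group goes against it. Nothing in the available data accounts for this reversal.

The compounds shown leave open whether the rise belongs to ring closure in general or to the piperidin-1-yl group alone, a question that a pyrrolidin-1-yl or morpholin-4-yl group on the same sulfonyl sulfur would address. They also leave open how far the open-chain series extends, for example to a dibutylamino group, and whether an azepan-1-yl ring would follow the piperidin-1-yl group or the open chains.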